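Ester in place of an amide side chain: half-life expectation

The compounds below may be only part of what the source reports. "The series", "measured", "known", "first", "only" and "open" are said of these compounds alone.

Measured compounds:
compound 1, `CCOc1cc(NC(=O)C2(NC(=O)c3ccc4c(C5CCCC5)c(-c5ncc(Cl)cn5)n(C)c4c3)CCC2)ccc1/C=C/C(=O)N[C@@H](CC(=O)O)C(N)=O`, 0.0667 h
compound 2, `CCOc1cc(NC(=O)C2(NC(=O)c3ccc4c(C5CCCC5)c(-c5ncc(Cl)cn5)n(C)c4c3)CCC2)ccc1/C=C/C(=O)N[C@@H](CCC(=O)O)C(N)=O`, 4.23 h

Within the data shown here, in an ADME assay for pharmacokinetics, in simulated intestinal fluid (on this read-out higher numbers stand for a longer-lived compound and lower numbers for a shorter-lived compound), compound 2 holds the higher of the two numbers, and the only measured step, a 63-fold higher number from compound 1 to compound 2 (1.80 log units; beyond the scatter), shows how far it stands from compound 1. Compound 3, `CCOC(=O)/C=C/c1ccc(NC(=O)C2(NC(=O)c3ccc4c(C5CCCC5)c(-c5ncc(Cl)cn5)n(C)c4c3)CCC2)cc1OCC`, differs from compound 2 by ethoxy in place of (1-carbamoyl-3-carboxypropyl)amino on a carbonyl carbon. Among the measured compounds shown here, no measured step touches this part of the molecule; the one measured step lies elsewhere, so it gives no guide here. In this assay the change from compound 2 to compound 3 is expected to read a 4.2-fold lower number from compound 2 to compound 3 (0.63 log units; beyond the scatter). Compound 3 is therefore estimated at 1 h, within 0.1 h to 10 h.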

Compound 3, half-life: > 5 h
Compound 3: no number, only a limit; the forecaster's own chance of this, stated with the estimate: 10%; middle value at least 5.0-fold (0.69 log units) from the limit.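

Compound 3 gives no number in this assay, only a limit: the limit of > 5 h in this assay, at which 1 of the 3 values shown sits.

From the compounds shown here alone, the step reads an at least 1.1-fold higher number from compound 2 to compound 3 (0.07 log units; that floor lies within the scatter), so putting ethoxy on this carbonyl carbon in place of the whole side chain costs no half-life, though the true size of the change stays unknown. Starting instead from the (1-carbamoyl-2-carboxyethyl)amino side chain, the step reads an at least 74-fold higher number from compound 1 to compound 3 (1.87 log units; beyond the scatter).

Going by these compounds, the true half-life of compound 3 remains open. So does whether a methoxy or a butoxy group on this carbonyl carbon would read as ethoxy does.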